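A few compounds are considered here, and "the series" means these few. Any claim that something is new, unique, unknown or untested is made for them only; others in the source may bear on it.

Among the compounds with values here, the three compounds measured so far share one core and differ in the group attached to it. In an in vitro assay on HEK293 cells for displacement of a labelled ligand from adenosine receptor A2b (Homo sapiens) (on this read-out higher numbers stand for weaker inhibition and lower numbers for stronger inhibition), compound 2 `CCCn1c(=O)c2nc(-c3cnn(Cc4cc(Cl)ccc4Cl)c3)[nH]c2n(CCC)c1=O` gives 29 nM, the lowest number of the three and therefore the strongest binding seen here. Compound 1 `CCCCn1c(=O)c2nc(-c3cnn(Cc4ccccc4)c3)[nH]c2n(CCCC)c1=O` gives 980 nM in this assay, and compound 3 `CCCn1c(=O)c2nc(-c3cc(C)nn3C)[nH]c2n(CCC)c1=O` gives 3700 nM; both gaps to compound 2 lie beyond the usual scatter. Compound 4 `CCCn1c(=O)c2nc(-c3cnn(Cc4c(F)cccc4F)c3)[nH]c2n(CCC)c1=O` has not yet been measured in this assay. It differs from compound 2 in one place: 2,6-difluorophenyl in place of 2,5-dichlorophenyl on a saturated chain carbon bound to an aromatic nitrogen. Within the data shown here, no measured pair shows this exact exchange, so its size can only be estimated. Compound 1 gives a much higher number than compound 2, but it also differs in other places, so that comparison is only a loose guide. The step is expected to be a moderate weakening, estimated at a 5.2-fold higher number from compound 2 to compound 4 (0.71 log units; beyond the scatter). Compound 4 is therefore expected to give about 150 nM in this assay, within a range of 40 nM to 600 nM.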

Compound 4, inhibition constant: 390 nM
Compound 4: the middle estimate sits 2.6-fold (0.41 log units) below what was measured; low and high end bracket the measured number.
By their numbers in this assay, from the lowest: compound 2; then compound 4; then compound 1; then compound 3.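

Within the data shown here, this is the first change here that can be read in one place: in this assay, replacing 2,5-dichlorophenyl with 2,6-difluorophenyl brings a 13-fold higher number from compound 2 to compound 4 (1.13 log units; beyond the scatter) and so a large loss of binding. The position on the saturated chain carbon bound to an aromatic nitrogen is therefore sensitive to what the phenyl ring carries, even though the two groups match in heavy atoms, with no hydrogen-bond donors or acceptors and no net charge on either. Nothing available explains why the number rises so much.

The step changes the halogen and its arrangement on the ring together, so the compounds shown cannot say which of the two matters more. From the compounds shown here alone, how a phenyl ring carrying methoxy groups or bromine atoms would behave in this place also remains open.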